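Urea in Place of Thiourea on a Sulfonamide Chain

This account rests on a few compounds, and the source may have more. Where it says the series, first, only, none or still open, it means among the compounds named here.

Measured so far:
Compound 1, `O=S(=O)(NCCNC(=S)Nc1cccc(Cl)c1)c1ccc(-c2ccccc2OCc2ccccc2)s1`, gives in a functional assay on HL-60 cells (Homo sapiens) for inhibition, read by CCK-8 assay, with a stated time of 48 h (a higher number here means a weaker inhibitor, a lower number a stronger inhibitor), only the assay limit > 50000 nM.
Compound 2, `O=C(NCCNS(=O)(=O)c1ccc(-c2ccccc2OCc2ccccc2)s1)Nc1cc(Cl)cc(Cl)c1`, gives 11700 nM.
Compound 3, `COc1ccc(NC(=S)NCCNS(=O)(=O)c2sccc2-c2ccc(C)cc2Oc2ccc(O)c(O)c2)cc1`, gives 4100 nM.

Compound 3 therefore holds the lowest of the two numbers, compound 2 sits higher, and compound 1 is known only as a limit, not as a number. Compound 4, `Cc1ccc(-c2ccsc2S(=O)(=O)NCCNC(=O)Nc2cccc([N+](=O)[O-])c2)c(Oc2ccc(O)c(O)c2)c1`, has not yet been measured. It differs from compound 3 in one place: a group of 12 heavy atoms (7 carbon, 2 nitrogen, 3 oxygen; one six-membered aromatic ring of carbon only) in place of a group of 11 heavy atoms (8 carbon, 1 nitrogen, 1 oxygen, 1 sulfur; one six-membered aromatic ring of carbon only), on an amine nitrogen. In plain terms, a sulfur-containing group on the chain nitrogen gives way to (3-nitrophenyl)carbamoyl. One measured step is of the same kind, since it too exchanges a sulfur-containing group for a carbamoyl group and alters the ring it carries: an at least 4.2-fold lower number from compound 1 to compound 2 (0.63 log units; beyond the scatter). That step starts from a limit (the limit of > 50000 nM in this assay, at which 1 of the 3 values shown sits), so only its lower bound is known. On this basis a lowering of the number is expected for compound 4, but compound 3 already has the lowest number shown, so a more cautious step is expected: a 1.6-fold lower number from compound 3 to compound 4 (0.21 log units; within the scatter). Compound 4 is estimated at 2500 nM, with a likely range from 800 nM to 8000 nM.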

Compound 4, half-maximal inhibitory concentration: 6000 nM
Beside the measured number, compound 4's estimate is 2.4-fold (0.38 log units) below it, and the stated range covers the measured number.
By their numbers in this assay, from the lowest: compounds 3, 4 and 2 (each within the scatter of the next, the first and the last beyond it). At a limit, above all of these: compound 1.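

In this assay, putting (3-nitrophenyl)carbamoyl in place of the sulfur-containing group on the amine nitrogen gives a 1.5-fold higher number from compound 3 to compound 4 (0.17 log units; within the scatter), and compound 3 and compound 4 cannot be told apart by this measurement. Among the compounds shown here, the one earlier step of this kind, made on a different core, went beyond the scatter, an at least 4.2-fold lower number from compound 1 to compound 2 (0.63 log units; beyond the scatter), and the new pair shows that this kind of exchange does not bring such a shift on every core, although only these two steps can be set side by side. That earlier step also starts from compound 1, which is known only as a limit, so its full size cannot be read: the limit of > 50000 nM in this assay, at which 1 of the 4 values shown sits.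

Both steps change the ring carried by the group along with the exchange of sulfur for oxygen, and the compounds shown include no pair that separates these two changes. Going by these compounds, it also remains open how compound 4 would respond if an amine or a carboxylic acid took the place of its nitro group, or if a longer chain replaced the saturated chain on the amine nitrogen.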